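A Ring Swap Tested Against Liver-Cell Toxicity

This account rests on a few compounds, and the source may have more. Where it says the series, first, only, none or still open, it means among the compounds named here.

In an ADME assay on HepG2 cells (Homo sapiens) for cytotoxicity, read by CellTiter-Glo and resazurin assay, with a stated time of 72 h (a lower number here means that less compound is needed, a higher number that more compound is needed for the effect), compound 1 `CC(C)Oc1cccc(-c2ccc(C(=O)N(Cc3cccc(OCCCCCC(=O)O)c3)C(C)C)cc2)c1` gives only a limit, > 26000 nM. Compound 2 `CCOC(=O)CCCCCOc1cccc(CN(C(=O)c2ccc(-c3cccnc3)cc2)C(C)C)c1` likewise gives only a limit in this assay, > 26000 nM. Both readings fall together, at the limit of > 26000 nM in this assay, at which 2 of the 2 values shown sit, so compound 2 stands at the edge of what this assay can report. Compound 3 `CCOC(=O)CCCCCOc1cccc(CN(C(=O)c2ccc(-c3ccc4c(c3)OCCO4)cc2)C(C)C)c1` differs from compound 2 in one place: 2,3-dihydro-1,4-benzodioxin-6-yl in place of pyridin-3-yl on an aromatic carbon. Because both measured compounds share (the limit of > 26000 nM in this assay, at which 2 of the 2 values shown sit), the step from compound 2 to compound 3 is expected to stay within the usual scatter, about a step that the limit leaves unreadable from compound 2 to compound 3. Compound 3 is expected to give 30000 nM, estimated between 15000 nM and 60000 nM.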

Compound 3, half-maximal effective concentration: > 24400 nM
Compound 3 gave a limit, no number (the forecaster's own chance of this, stated with the estimate: 75%); the middle value lies beyond the limit too.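

Within the data shown here, compound 2 and compound 3 both give only limits in this assay, so no step between them can be read. Going by these compounds, what concentration either compound needs for the effect, and whether the ring swap changes it, stays open.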